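This account rests on a few compounds, and the source may have more. Where it says the series, first, only, none or still open, it means among the compounds named here.

Measured so far in a functional assay on HT-29 cells (Homo sapiens) for cytotoxicity, read by resazurin assay, with a stated time of 48 h; a higher number here means that more compound is needed for the effect, a lower number that less compound is needed:
- compound 1 `O=C(Nc1ccc(Sc2nc3ccccc3s2)c(Cl)c1)c1cccc(Br)c1O`: 20000 nM
- compound 2 `COc1c(Br)cccc1C(=O)Nc1ccc(Sc2nc3ccccc3s2)cc1`: 30000 nM

Going by the values given here, the series is small, with two measured compounds and no pair among them that differs in one place only. In this assay compound 2 gives 30000 nM, which lies within the scatter of compound 1 at 20000 nM. Neither compound can be ranked over the other on these numbers.

The next compound is compound 3 `COc1c(Br)cccc1C(=O)Nc1ccc(Sc2nc3ccccc3s2)c(Cl)c1`. It differs from compound 2 by chloro in place of hydrogen on an aromatic carbon, ortho to a large group and meta to a large group: chloro in place of hydrogen on an aromatic carbon.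

Among the compounds with values here, no measured step shows how such a replacement acts in this assay, so there is no direct precedent for its size or direction. Within the data shown here, the only guide is the narrow spread of the two known values, compound 1 at 20000 nM and compound 2 at 30000 nM. No change beyond the scatter is therefore expected, and no firm direction. The estimated step is a 1.2-fold lower number from compound 2 to compound 3 (0.08 log units; within the scatter). For compound 3 the expected value is 25000 nM, with an estimated range of 10000 nM to 60000 nM.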

Compound 3, half-maximal effective concentration: 11000 nM
Compound 3: middle estimate off by 2.3-fold (0.36 log units), on the high side; the measured number falls inside the stated range.
By their numbers in this assay, from the lowest: compounds 3, 1 and 2 (each within the scatter of the next, the first and the last beyond it).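

In this assay, going by these compounds alone, chloro in place of hydrogen on an aromatic carbon, ortho to a large group and meta to a large group, gives a 2.7-fold lower number from compound 2 to compound 3 (0.44 log units; beyond the scatter) and is the first step to lie beyond the scatter, although only a modest one. This gives the position its first measured sign that a single added chlorine can shift the read-out, but it rests on one pair of compounds. The other new step, methyl in place of hydrogen on an oxygen on an aromatic ring, gives a 1.8-fold lower number from compound 1 to compound 3 (0.26 log units; within the scatter) and stays within the scatter, so this pair cannot be ordered, and no data bear on what lies behind either step.

The compounds shown leave open whether the chloro step holds when that oxygen carries hydrogen rather than methyl, and whether fluoro or trifluoromethyl at the same place would give a step of similar size. Going by these compounds, it also remains open whether a nitrile in place of the bromo would move compound 3 from its 11000 nM in this assay by more than the scatter.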